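Swapping a Sulfonylcarbamate for a Furoate Ester

The source may hold more compounds than are shown below. What is called first, only, known or untested is meant among the compounds shown, and "the series" means these compounds.

In a functional assay on MCF7 cells (Homo sapiens) for antiproliferative activity, read by MTT assay, with a stated time of 72 h (on this read-out lower numbers stand for stronger inhibition and higher numbers for weaker inhibition), compound 2 `CC1=CC[C@H]2[C@H](CC[C@]2(C)O)C(C)(C)[C@@H]1CC[C@H]1[C@]2(C)CC[C@H](OC(=O)NS(=O)(=O)c3ccc(C)cc3)C(C)(C)O[C@H]2CC[C@@]1(C)O` reaches only the limit of the assay, > 50000 nM, so no number is known for it. Compound 1 `CC1=CC[C@H]2[C@@H]1CC=C(C)[C@@H](CC[C@H]1[C@]3(C)CC[C@H](O)C(C)(C)O[C@H]3CC[C@@]1(C)O)C2(C)C` likewise gives only the limit, > 50000 nM. Both measured values therefore sit at the same ceiling (the limit of > 50000 nM in this assay, at which 2 of the 2 values shown sit). Compound 3 `CC1=CC[C@H]2[C@H](CC[C@]2(C)O)C(C)(C)[C@@H]1CC[C@H]1[C@]2(C)CC[C@H](OC(=O)c3ccco3)C(C)(C)O[C@H]2CC[C@@]1(C)O` is built from compound 2 by one change: furan-2-yl in place of ((4-methylphenyl)sulfonyl)amino on a carbonyl carbon. Going by the values given here, no step between measured compounds is available, so the expected step of a number no higher from compound 2 to compound 3 (the limit leaves the size open) is none beyond the scatter. Compound 3 is estimated at 50000 nM, with a likely range from 20000 nM to 120000 nM, most probably again reported only as a limit.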

Compound 3, half-maximal inhibitory concentration: 25700 nM
Estimate against measurement, compound 3: 1.9-fold (0.29 log units) above; the measured number falls inside the stated range.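

In this assay compound 3 is the only compound shown with a number rather than a limit, so furan-2-yl on this carbonyl carbon gives a reading that ((4-methylphenyl)sulfonyl)amino did not. The change gives an at least 1.9-fold lower number from compound 2 to compound 3 (0.28 log units; that floor lies within the scatter) as its step. Its true size cannot be read because compound 2 is known only as a limit: the limit of > 50000 nM in this assay, at which 2 of the 3 values shown sit.

The compounds shown leave open whether a plain phenyl ring or a simple amine on the same carbonyl carbon would also give a number, and how that number would compare.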